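Swapping a Hydroxyl for Fluorine on the Imine Aryl

The compounds below may be only part of what the source reports. "The series", "measured", "known", "first", "only" and "open" are said of these compounds alone.

In an assay on isolated protein for inhibition of Amine oxidase [flavin-containing] B (Homo sapiens), read by fluorescence and Amplex Red, with stated times of 15 min and 20 min (on this read-out lower numbers stand for stronger inhibition and higher numbers for weaker inhibition), compound 2 `Oc1cccc(/C=N/c2ccc(OCc3ccccc3)cc2)c1O` gives 6870 nM, the second highest of three numbers. Compound 1 `COc1cccc(/C=N/c2ccc(OCc3ccccc3)cc2)c1O` gives 6500 nM, and the step of a 1.1-fold higher number from compound 1 to compound 2 (0.02 log units; within the scatter) lies within the scatter. Compound 3 `Oc1ccc2ccccc2c1/C=N/c1ccc(OCc2ccccc2)cc1` gives 19200 nM, a value beyond the scatter from that of compound 2. Compound 4 `Oc1ccc(F)cc1/C=N/c1ccc(OCc2ccccc2)cc1` is not yet measured; it differs from compound 2 by 5-fluoro-2-hydroxyphenyl in place of 2,3-dihydroxyphenyl on a carbon with a double bond to nitrogen. Within the data shown here, only the step from compound 1 to compound 2 bears on this change, and it shows that altering one oxygen on that ring produces no shift beyond the scatter. Among the measured compounds shown here, no measured step covers fluorine or the loss of a hydroxyl, so a small weakening or none beyond the scatter is expected. Compound 4 is therefore estimated at 9000 nM, between 3500 nM and 23000 nM, the expected step of a 1.3-fold higher number from compound 2 to compound 4 (0.12 log units; within the scatter) being modest.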

Compound 4, half-maximal inhibitory concentration: 15300 nM
Beside the measured number, compound 4's estimate is 1.7-fold (0.23 log units) below it; measured number inside the range.
By their numbers in this assay, from the lowest: compounds 1 and 2 (each within the scatter of the next); then compounds 4 and 3 (each within the scatter of the next).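

Unlike the change at one oxygen between compound 1 and compound 2, this swap on the carbon with a double bond to nitrogen moves the number beyond the scatter, with inhibition weakening by a 2.2-fold higher number from compound 2 to compound 4 (0.35 log units; beyond the scatter). The result shows that this position is sensitive to the ring it carries, but the step cannot be pinned on gaining fluorine or losing a hydroxyl alone. No measurement here accounts for the shift. Open, as far as these compounds go, is how a plain 2-hydroxyphenyl group would compare, and whether an amine in fluorine's place would restore inhibition.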